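The source may report more compounds than this note shows. Statements on the series, on what has been measured and on what is new or still open speak of the compounds shown alone.

Compound 1 `C=C(Br)C(=O)Nc1ccc(/C=C/C(=O)c2ccccc2)cc1` carries the shared core with a hydrogen at the position of interest. Among the compounds with values here, in a functional assay on MOLT-4 cells (Homo sapiens) for antiproliferative activity, with a stated time of 48 h (a lower number here means a stronger inhibitor, a higher number a weaker inhibitor), compound 1 gives 3100 nM, the highest of the two numbers measured so far, its nearest neighbour being compound 2. Compound 2 `C=C(Br)C(=O)Nc1ccc(/C=C/C(=O)c2ccc(C)cc2)cc1`, with a methyl in place of hydrogen on an aromatic carbon, gives 1700 nM in this assay; the step of a 1.8-fold lower number from compound 1 to compound 2 (0.26 log units; within the scatter) stays within the scatter. Compound 3 `C=C(Br)C(=O)Nc1ccc(/C=C/C(=O)c2ccc(OCC)cc2)cc1` has not yet been measured in this assay. It differs from compound 1 by ethoxy in place of hydrogen on an aromatic carbon, the ethoxy sitting para to a large group. Within the data shown here, the only measured step that bears on this change is the one from compound 1 to compound 2, and that stayed within the scatter; no measured pair shows an ethoxy at this place. Compound 3 is therefore expected to sit close to compound 1, and a 1.4-fold lower number from compound 1 to compound 3 (0.15 log units; within the scatter) is expected to remain within the scatter. Compound 3 is estimated at 2200 nM, in the range 800 nM to 6000 nM.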

Compound 3, half-maximal inhibitory concentration: 610 nM
Beside the measured number, compound 3's estimate is 3.6-fold (0.56 log units) above it; measured number below the stated range.
By their numbers in this assay, from the lowest: compound 3; then compounds 2 and 1 (each within the scatter of the next).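

Within the data shown here, on the aromatic carbon para to a large group, ethoxy gives the first step in this assay that lies beyond the scatter, with a 5.1-fold lower number from compound 1 to compound 3 (0.71 log units; beyond the scatter), whereas the methyl of compound 2 did not move the number beyond it. Ethoxy in place of methyl at this same place also gives a step beyond the scatter, with a 2.8-fold lower number from compound 2 to compound 3 (0.45 log units; beyond the scatter), so this position responds to the group placed there and the two groups are not interchangeable. Nothing available here accounts for this difference.

The compounds shown leave open whether the oxygen or the two-carbon chain of the ethoxy carries the step, since neither a methoxy nor a propyl chain stands at this place among them. On these data alone, how a longer alkoxy chain or an amine at this place would read also remains open.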